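From benzoyl to benzyloxycarbonyl on a shared core

A few compounds are considered here, and "the series" means these few. Any claim that something is new, unique, unknown or untested is made for them only; others in the source may bear on it.

compound 1 `C=C[C@@](C)(/C=C/c1ccc(O)cc1)CC/C=C/C#N`: > 43400 nM (a limit, not a number)
compound 2 `C=C[C@@](C)(/C=C/c1ccc(O)c(C=O)c1)CCC=C(C)C`: 11200 nM
compound 3 `C=C[C@@](C)(/C=C/c1ccc(O)c(/C=C/C(=O)c2ccccc2)c1)CCC=C(C)C`: 4470 nM

These three results come from a functional assay on NALM-6 cells (Homo sapiens) for cytotoxicity, with a stated time of 72 h; a lower number here means that less compound is needed, a higher number that more compound is needed for the effect. For compound 1 the reading is only a limit (> 43400 nM). Among the two exact numbers, compound 3 has the lower (4470 nM). Its nearest neighbour, compound 2, stands higher (11200 nM), and that gap lies beyond the scatter.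

Compound 4 `C=C[C@@](C)(/C=C/c1ccc(O)c(/C=C/C(=O)OCc2ccccc2)c1)CCC=C(C)C` has not yet been measured. It departs from compound 3 at a single place, with benzyloxy in place of phenyl on a carbonyl carbon. Among the measured compounds shown here, no measured pair shows this change, so the expectation rests on compound 3 (4470 nM) and on the modest spread of the two exact numbers. No change beyond the scatter is expected in this assay, with a slight rise as the likelier direction. The expected move is a 1.3-fold higher number from compound 3 to compound 4 (0.13 log units; within the scatter), an estimate that stays within the scatter. For compound 4 the estimated value is 6000 nM, with an expected range from 2500 nM to 15000 nM.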

Compound 4, half-maximal effective concentration: > 43400 nM
Compound 4: a limit, no number; the forecaster's own chance of this, stated with the estimate: 10%; at least 7.2-fold (0.85 log units) between middle value and limit.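

In this assay, setting benzyloxy in place of phenyl on a carbonyl carbon, which turns benzoyl into benzyloxycarbonyl, gives an at least 9.7-fold higher number from compound 3 to compound 4 (0.98 log units; beyond the scatter). The earlier compounds shown here gave no reading of this place, and the step now shows that it is sensitive to what the carbonyl carbon carries, even though both groups hold one six-membered aromatic ring of carbon only. The reading for compound 4 is a limit and not a number, so the step gives only a minimum size: the limit of > 43400 nM in this assay, at which 2 of the 4 values shown sit.

The compounds shown leave open whether the oxygen that enters or the greater size of the group matters more, and a plain methoxy or a benzylamino group on the same carbonyl carbon would help to separate the two. They also leave open how a carboxylic acid at this place would read.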